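Chloro to Methoxy Across Two Cores in a Mouse Read-Out

The compounds below may be only part of what the source reports. "The series", "measured", "known", "first", "only" and "open" are said of these compounds alone.

Compound 1, `CC(=O)c1cccn1CCCN1CCN(c2cccc(Cl)c2)CC1`, is the starting point. In a functional assay on the whole organism (Abdomen, strain Swiss) for inhibition, with Mus musculus as the target, with stated times of 30 min, 10 min and 5 min, at a dose of 10 mg/kg by the oral route (on this read-out lower numbers stand for a weaker effect and higher numbers for a stronger effect at the one dose given), compound 1 gives 3%. Compound 2, `COc1cccc(N2CCN(CCCn3cccc3C(C)=O)CC2)c1`, carries one alteration: methoxy in place of chloro on an aromatic carbon. This brings a number 3 percentage points lower from compound 1 to compound 2 (within the scatter), so the swap leaves the read-out essentially where it was. In this assay compound 2 gives 0%.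

Compound 3, `O=c1occ(-c2ccccc2)n1CCCN1CCN(c2cccc(Cl)c2)CC1`, is built on a different core; how that core differs from the core of compound 1 is not broken down here. In this assay compound 3 gives 7%, a number that does not stand apart from those of compound 1 or compound 2.

Compound 4, `COc1cccc(N2CCN(CCCn3c(-c4ccccc4)coc3=O)CC2)c1`, has not yet been measured. It differs from compound 3 by methoxy in place of chloro on an aromatic carbon, the same change that turns compound 1 into compound 2. Because compound 1 to compound 2 showed a number 3 percentage points lower from compound 1 to compound 2 (within the scatter), the step from compound 3 to compound 4 is expected to be small, around a number 3 percentage points lower from compound 3 to compound 4 (within the scatter). Compound 4 is therefore estimated at 4%, with a likely range from 0% to 12%.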

Compound 4, a percentage reported as inhibition, in the whole organism at one dose (the size of the read-out at that dose, not a potency): 8%
For compound 4 the middle estimate is 4 percentage points below the measured one, within the range that was stated.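

On the second core, putting methoxy in place of chloro brings a number 1 percentage points higher from compound 3 to compound 4 (within the scatter) in this assay, so here too the swap leaves the read-out essentially where it was. Set side by side, the two steps do not differ, which means the swap behaves alike on both cores: the same change on two cores in this assay, a number 3 percentage points lower (within the scatter) from compound 1 to compound 2 and a number 1 percentage points higher (within the scatter) from compound 3 to compound 4, 4 percentage points apart, within the scatter of two such steps. For the compounds shown here, this agreement is limited, though: it rests on only two pairs, both with small numbers at a single dose, so it does not show that the swap would stay this quiet on a core with a clearly stronger effect, or on any core beyond these two.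

The compounds shown leave open whether a different group in that same place on the ring, such as trifluoromethyl or an amine, would move the read-out beyond the usual scatter. They also leave open whether a longer chain joining the core to the rest of the molecule would change the picture.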